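Series notes: aryl extension on the piperazine of compound 3

The source may hold more compounds than are shown below. What is called first, only, known or untested is meant among the compounds shown, and "the series" means these compounds.

Of the compounds shown here, three of a shared core have been measured in a functional assay on MCF7 cells (Homo sapiens) for cytotoxicity, read by MTT assay, with a stated time of 24 h, tested at 0.64 ug/mL; on this read-out higher numbers stand for a stronger effect at the one concentration tested and lower numbers for a weaker effect. Compound 1 `Cn1c(-c2ccc(NC(=O)CSc3nc4cc(Cl)ccc4o3)cc2)nc(-c2ccccc2)c1-c1ccccc1` gives 2.4%, compound 2 `Cn1ccnc1SCC(=O)Nc1ccc(-c2nc(-c3ccccc3)c(-c3ccccc3)n2C)cc1` gives 10.3% and compound 3 `CN1CCN(CC(=O)Nc2ccc(-c3nc(-c4ccccc4)c(-c4ccccc4)n3C)cc2)CC1` gives 1.1%. Compound 3 holds the lowest of the three numbers, yet the steps of a number 1.3 percentage points lower from compound 1 to compound 3 (within the scatter) and a number 9.2 percentage points lower from compound 2 to compound 3 (within the scatter) both lie within the scatter, as does a number 7.9 percentage points higher from compound 1 to compound 2 (within the scatter); across the whole set no change has moved this read-out beyond the scatter.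

Compound 4 `Cc1ccc(CN2CCN(CC(=O)Nc3ccc(-c4nc(-c5ccccc5)c(-c5ccccc5)n4C)cc3)CC2)cc1` differs from compound 3 by 4-methylphenyl in place of hydrogen on a saturated chain carbon bound to an amine nitrogen in a ring. Among the measured compounds shown here, none of the measured steps touches this place: all three exchange the group on the saturated chain carbon bound to the carbonyl carbon, and none adds a 4-methylphenyl anywhere. For the measured compounds named here, the measured steps therefore bear on the new change only indirectly, through showing that the series so far has stayed flat in this assay. No step beyond the scatter is expected for a number 3.9 percentage points higher from compound 3 to compound 4 (within the scatter). Compound 4 is estimated at 5%, with a range from 0% to 20%.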

Compound 4, a percentage reported as activity, at one concentration (the size of the read-out at that concentration, not a potency): 9.4%
The estimate for compound 4 lay 4.4 percentage points below the measured number, and the stated range covers the measured number.
By their numbers in this assay, from the lowest: compounds 3, 1, 4 and 2 (each within the scatter of the next).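

Among the compounds shown here, this is the first reading at the place on a saturated chain carbon bound to an amine nitrogen in a ring: in this assay, 4-methylphenyl in place of hydrogen gives a number 8.3 percentage points higher from compound 3 to compound 4 (within the scatter), so the change from methyl to 4-methylbenzyl adds 7 heavy atoms and one six-membered aromatic ring without a step beyond the scatter. The flat picture therefore now extends from the saturated chain carbon bound to the carbonyl carbon to this second place in the series. Nothing available explains the result or links it to any property of the group.

Open, on these data alone, is whether a group carrying a carboxylic acid, an amine or a longer chain at this place would move the number beyond the scatter. A single tested concentration also leaves the potency of compound 4 open.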